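Alkynyl chain length in a nucleoside series

The source may hold more compounds than are shown below. What is called first, only, known or untested is meant among the compounds shown, and "the series" means these compounds.

Compound 1 `CC#Cc1cn([C@H]2C[C@H](O)[C@@H](CO)O2)c(=O)[nH]c1=O`, compound 2 `CCC#Cc1cn([C@H]2C[C@H](O)[C@@H](CO)O2)c(=O)[nH]c1=O` and compound 3 `CCCCCC#Cc1cn([C@H]2C[C@H](O)[C@@H](CO)O2)c(=O)[nH]c1=O` share one core and differ only in the chain on the triple-bonded carbon. Compound 4 `CCCCC#Cc1cn([C@H]2C[C@H](O)[C@@H](CO)O2)c(=O)[nH]c1=O` is the member not yet measured. In an ADME assay on L1210/0 cells (Mus musculus) for cytotoxicity, with a stated time of 48 h (on this read-out higher numbers stand for weaker inhibition and lower numbers for stronger inhibition), compound 1 gives > 200000 nM, a limit of the assay and not a number. Compound 2 gives > 200000 nM, likewise a limit. Compound 3 gives > 200000 nM, again a limit. Because (the limit of > 200000 nM in this assay, at which 3 of the 3 values shown sit), none of the three steps among them can be read: a step that the two limits leave unreadable from compound 2 to compound 1, a step that the two limits leave unreadable from compound 1 to compound 3 and a step that the two limits leave unreadable from compound 2 to compound 3 are all unreadable.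

The change from compound 2 to compound 1 is hydrogen in place of methyl on a saturated chain carbon bound to a triple-bonded carbon. The same change, which occurs twice among the compounds shown, is made from compound 3 to compound 4: hydrogen in place of methyl on a saturated chain carbon, four bonds along the chain from a triple-bonded carbon. The two places are not the same word for word: in the first it sits on a saturated chain carbon bound to a triple-bonded carbon, in the second on a saturated chain carbon four bonds along the chain from a triple-bonded carbon, so it is the same kind of change, not the same. The cores of compound 2 and compound 3 differ by propyl in place of hydrogen on a saturated chain carbon, two bonds along the chain from a triple-bonded carbon.

In this assay the expected step is a step that the limit leaves unreadable from compound 3 to compound 4, set beside the unreadable measured a step that the two limits leave unreadable from compound 2 to compound 1. That expectation rests on compound 3, whose > 200000 nM is a limit. For compound 4 the estimate is 300000 nM, most likely again reported as a limit.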

Compound 4, half-maximal inhibitory concentration: > 200000 nM
Compound 4: a limit, no number; the forecaster's own chance of this, stated with the estimate: 85%; the middle value does not contradict the limit.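

In this assay compound 4 gives > 200000 nM, a limit of the assay and not a number. No new step linking compound 4 with compound 1, compound 2 or compound 3 can be read, because all four compounds share one limit: the limit of > 200000 nM in this assay, at which 4 of the 4 values shown sit.

The compounds shown leave open whether chain length on the triple-bonded carbon has any effect on this read-out.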